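The source may report more compounds than this note shows. Statements on the series, on what has been measured and on what is new or still open speak of the compounds shown alone.

Three compounds built on one shared core differ only in the group on a saturated chain carbon bound to an aromatic nitrogen. Compound 1 `CNC(=O)c1cc(C(=O)NC2CC2)cn(CC2CCCOC2)c1=O` carries oxan-3-yl there, compound 2 `CNC(=O)c1cc(C(=O)NC2CC2)cn(Cc2cccc3[nH]ccc23)c1=O` carries 1H-indol-4-yl, and compound 3 `CNC(=O)c1cc(C(=O)NC2CC2)cn(Cc2ccc(F)cc2)c1=O` carries 4-fluorophenyl. In a physicochemical assay for solubility (on this read-out lower numbers stand for lower solubility and higher numbers for higher solubility), compound 1 reaches a limit of the assay rather than a number, >= 131 ug/mL. Compound 2 gives 78 ug/mL in this assay. Compound 3 also stops at a limit, >= 162 ug/mL. Comparing the measured pairs, an at least 2.0-fold higher number from compound 2 to compound 3 (0.31 log units; beyond the scatter), whereas an at least 1.6-fold lower number from compound 1 to compound 2 (0.22 log units; that floor lies within the scatter) and a step that the two limits leave unreadable from compound 1 to compound 3.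

Within the data shown here, compound 4 `CNC(=O)c1cc(C(=O)NC2CC2)cn(Cc2cccc(C#N)c2)c1=O` has not yet been measured. 3-cyanophenyl in place of 4-fluorophenyl on a saturated chain carbon bound to an aromatic nitrogen Every measured step involves oxan-3-yl or 1H-indol-4-yl, so none of them mirrors an exchange of one six-membered aromatic ring of carbon only for another, and the change in hand has no close measured counterpart. The step of an at least 1.2-fold lower number from compound 3 to compound 4 (0.09 log units; that floor lies within the scatter) is therefore expected to stay within the scatter, with some chance that compound 4 again reaches a limit. The estimate for compound 4 in this assay is 130 ug/mL, in a range from 55 ug/mL to 250 ug/mL.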

Compound 4, solubility: >= 148 ug/mL
Compound 4 was reported as a limit (the forecaster's own chance of this, stated with the estimate: 40%); middle value at least 1.1-fold (0.05 log units) from the limit.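

At this position, on a saturated chain carbon bound to an aromatic nitrogen, compound 4 shows that 3-cyanophenyl also ends at a limit of this assay rather than at a number, as 4-fluorophenyl and oxan-3-yl did: the limit of >= 148 ug/mL in this assay, at which 1 of the 4 values shown sits. Among these compounds, the one readable comparison is an at least 1.8-fold higher number from compound 2 to compound 4 (0.27 log units; that floor lies within the scatter), so this floor alone does not set the 3-cyanophenyl compound apart from the 1H-indol-4-yl compound. The steps joining compound 4 to compound 1 and to compound 3 cannot be read, with a limit at both ends of each.

Going by these compounds, what numbers lie behind the limits of compound 1, compound 3 and compound 4 stays open, so the exchange of 4-fluorophenyl for 3-cyanophenyl has no size yet. Also open, on these data alone, is what an amine or a carboxylic acid in this place would give.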